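Substituent swap on the ether-linked aromatic ring, compound 3

The source may report more compounds than this note shows. Statements on the series, on what has been measured and on what is new or still open speak of the compounds shown alone.

Measured so far in a functional assay on SW480 cells (Homo sapiens) for antiproliferative activity, read by MTT assay, with a stated time of 48 h; on this read-out higher numbers stand for weaker inhibition and lower numbers for stronger inhibition:
compound 1 `CCc1ccc(OCc2cn(-c3cc(=O)oc4ccc(Br)cc34)nn2)cc1` — 10800 nM
compound 2 `Nc1ccc(OCc2cn(-c3cc(=O)oc4ccc(Br)cc34)nn2)cc1` — 2090 nM

Compound 2 gives the lower of the two numbers in this assay. Within the data shown here, the single measured step bears directly on it: a 5.2-fold lower number from compound 1 to compound 2 (0.71 log units; beyond the scatter). Among the measured compounds shown here, that is the only step available, and it runs from a group with no hydrogen-bond donor or acceptor to one that brings both.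

Compound 3 `O=c1cc(-n2cc(COc3ccc(C(F)(F)F)cc3)nn2)c2cc(Br)ccc2o1` is not yet measured. Its change from compound 2 is trifluoromethyl in place of amino on an aromatic carbon. The group that enters brings no donor and no acceptor, which puts compound 3 in this respect on the side of compound 1 rather than compound 2. The step is therefore expected to run opposite to the measured one, toward a higher number and back toward the region of compound 1, while the size of the group that enters differs from ethyl, so the size of the return is uncertain. The expected step is a 3.8-fold higher number from compound 2 to compound 3 (0.58 log units; beyond the scatter). Compound 3 is estimated at 8000 nM, with a range from 3000 nM to 25000 nM.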

Compound 3, half-maximal inhibitory concentration: 3090 nM
Beside the measured number, compound 3's estimate is 2.6-fold (0.41 log units) above it, within the range that was stated.
By their numbers in this assay, from the lowest: compounds 2 and 3 (each within the scatter of the next); then compound 1.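

In this assay, trifluoromethyl in place of amino, on an aromatic carbon para to a large group, gives a 1.5-fold higher number from compound 2 to compound 3 (0.17 log units; within the scatter), so this position tolerates this exchange without a change that can be read beyond the scatter, even though the hydrogen-bond donor and acceptor of amino are lost. Trifluoromethyl in place of ethyl gives a 3.5-fold lower number from compound 1 to compound 3 (0.54 log units; beyond the scatter), and since neither group brings a donor or an acceptor, compound 3 goes against the reading of the earlier step as a matter of donors and acceptors alone. Nothing available here accounts for the separation of compound 1 from compound 2 and compound 3.

The compounds shown leave open whether ethyl stands apart as a single case or whether a longer chain, such as propyl, lies in the same region as compound 1. They also leave open where a methoxy group or a carboxylic acid at this position would fall relative to amino and trifluoromethyl, so no ordering of substituents can yet be drawn beyond these three compounds.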